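The source may report more compounds than this note shows. Statements on the series, on what has been measured and on what is new or still open speak of the compounds shown alone.

Compound 1 `O=S(=O)(c1cccc(F)c1)c1cn(C2CCNC2)c2ncccc12`, compound 2 `O=S(=O)(c1cccc(Br)c1)c1cn(C2CCNC2)c2ncccc12` and compound 3 `O=S(=O)(c1cccc(Br)c1)c1cn(C2CCCNC2)c2ncccc12` share a core and differ only at two spots. In a functional assay on HeLa cells for agonist activity at 5-hydroxytryptamine receptor 6 (Homo sapiens), read by cAMP accumulation and immunoassay (a lower number here means that less compound is needed, a higher number that more compound is needed for the effect), compound 2 gives 35 nM, compound 1 gives 278 nM, and compound 3 gives 72 nM. The change fluoro in place of bromo on an aromatic carbon produced a 7.9-fold higher number from compound 2 to compound 1 (0.90 log units; beyond the scatter). The cores of compound 2 and compound 3 differ by piperidin-3-yl in place of pyrrolidin-3-yl on an aromatic nitrogen, which produced a 2.1-fold higher number from compound 2 to compound 3 (0.31 log units; beyond the scatter). Compound 4 `O=S(=O)(c1cccc(F)c1)c1cn(C2CCCNC2)c2ncccc12` is not yet measured; it differs from compound 3 by fluoro in place of bromo on an aromatic carbon, the same change as from compound 2 to compound 1, at a place described in the same words. Because that earlier change gave a 7.9-fold higher number from compound 2 to compound 1 (0.90 log units; beyond the scatter), a step of similar size is expected here, a 7.6-fold higher number from compound 3 to compound 4 (0.88 log units; beyond the scatter). Compound 4 is therefore estimated at 550 nM, between 200 nM and 1500 nM.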

Compound 4, half-maximal effective concentration: 67 nM
Compound 4: the middle estimate sits 8.2-fold (0.91 log units) above what was measured, and the stated range ends above it.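

In this assay, fluoro in place of bromo on the core carrying piperidin-3-yl gives a 1.1-fold lower number from compound 3 to compound 4 (0.03 log units; within the scatter), so this step does not carry over from the core carrying pyrrolidin-3-yl: the same change on two cores in this assay, a 7.9-fold higher number (0.90 log units; beyond the scatter) from compound 2 to compound 1 and a 1.1-fold lower number (0.03 log units; within the scatter) from compound 3 to compound 4, 8.5-fold (0.93 log units) apart, beyond the scatter of two such steps. Seen from the other side, piperidin-3-yl in place of pyrrolidin-3-yl gives a 4.1-fold lower number from compound 1 to compound 4 (0.62 log units; beyond the scatter) when the compounds carry 3-fluorophenyl, the opposite direction to the step seen with 3-bromophenyl: the same change on two cores in this assay, a 2.1-fold higher number (0.31 log units; beyond the scatter) from compound 2 to compound 3 and a 4.1-fold lower number (0.62 log units; beyond the scatter) from compound 1 to compound 4, 8.5-fold (0.93 log units) apart, beyond the scatter of two such steps. The effects of the two changes therefore depend on each other in these compounds, but this small set does not show why, or whether the same holds elsewhere in the series.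

On these data alone, it remains open whether a chloro or methoxy group on the same aromatic carbon would behave like fluoro or bromo. As far as these compounds go, the effect of an azetidin-3-yl group on the aromatic nitrogen also remains open.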